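The source may hold more compounds than are shown below. What is called first, only, known or untested is meant among the compounds shown, and "the series" means these compounds.

Measured compounds:
- compound 1, `COc1ccccc1-c1cc(C(C)(C)C)cc(C(C)C)c1CO`: 820 nM
- compound 2, `CC(C)c1cc(C(C)(C)C)cc(-c2cccc(N(C)C)c2)c1CO`: 310 nM

Both compounds share the same core and were tested in a functional assay on RKE cells for antagonist activity at Vasoactive intestinal polypeptide receptor 1 (Rattus norvegicus), read by HTRF and cAMP accumulation, with stated times of 10 min and 30 min; on this read-out lower numbers stand for stronger inhibition and higher numbers for weaker inhibition. Compound 2 gives 310 nM, the lowest number of the two. Compound 1 gives 820 nM, a higher number than compound 2, and the gap between the two lies beyond the usual scatter of this assay.

The next step leads to compound 3, `CC(C)c1cc(C(C)(C)C)cc(-c2cccc(Cl)c2)c1CO`, which is not yet measured. It differs from compound 2 in one place: chloro in place of dimethylamino on an aromatic carbon. The leaving group carries one hydrogen-bond acceptor and the entering group carries none, and the entering group is a single heavy atom where the leaving group had three. Going by the values given here, no measured pair in this set makes this exchange, so there is no step on record to lean on, and the direction and size of the change in this assay are open.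

Compound 3 is therefore estimated near 450 nM, within a range of 150 nM to 1500 nM. That estimate corresponds to a step of a 1.5-fold higher number from compound 2 to compound 3 (0.16 log units; within the scatter), which is expected to stay close to the scatter, with a slightly weaker outcome held as more likely than a stronger one.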

Compound 3, half-maximal inhibitory concentration: 100 nM
Beside the measured number, compound 3's estimate is 4.5-fold (0.65 log units) above it; the measured number lies below the stated range.
By their numbers in this assay, from the lowest: compound 3; then compound 2; then compound 1.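

In this assay, the ring carbon meta to a large group turns out to be sensitive to what it carries: chloro in place of dimethylamino gives a 3.1-fold lower number from compound 2 to compound 3 (0.49 log units; beyond the scatter), a modest step but one beyond the usual scatter. A single chlorine atom therefore does better here than the three heavy atoms of dimethylamino, and the hydrogen-bond acceptor counted on dimethylamino is not required for this level of inhibition, since compound 3 has the lower number without it. No measured information on these groups accompanies the step, so the numbers record the gain without explaining it.

This single exchange changes the atom count and the acceptor count together, so the compounds shown cannot say which of the two, if either, goes with the lower number. Going by these compounds, whether chloro itself matters remains open too, and a fluoro, methyl or nitrile group on the same ring carbon would show whether other small groups give a similar number in this assay.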